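The source may report more compounds than this note shows. Statements on the series, on what has been measured and on what is new or still open speak of the compounds shown alone.

Working notes on the series. The compounds share one core bearing a piperidine-type amine whose substituent varies. Compound 1 `CC(C)OC(=O)N1CCC(CCCC(=O)c2ncco2)CC1` gives 4 nM in an assay on isolated protein for inhibition of Fatty-acid amide hydrolase 1 (Homo sapiens); a higher number here means a weaker inhibitor, a lower number a stronger inhibitor. Compound 2 `Cc1ccc(CN2CCC(CCCC(=O)c3ncco3)CC2)cc1` gives 400 nM, and compound 3 `O=C(CCCC1CCN(Cc2ccc(Cl)cc2)CC1)c1ncco1` gives 66 nM, the second highest number of the three measured. The change to compound 4 `CC(C)Oc1ccc(CN2CCC(CCCC(=O)c3ncco3)CC2)cc1` is isopropoxy in place of chloro on an aromatic carbon. Among the compounds with values here, only one measured step touches the same aromatic carbon: a 6.1-fold lower number from compound 2 to compound 3 (0.78 log units; beyond the scatter), a modest shift. The two steps from the carbamate of compound 1, a 100-fold higher number from compound 1 to compound 2 (2.00 log units; beyond the scatter) and a 17-fold higher number from compound 1 to compound 3 (1.22 log units; beyond the scatter), were large but concern a different position. Within the data shown here, no isopropoxy analogue exists here, so a modest step in either direction is expected, a 2.3-fold higher number from compound 3 to compound 4 (0.36 log units; beyond the scatter). Compound 4 is estimated at 150 nM, between 40 nM and 600 nM.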

Compound 4, half-maximal inhibitory concentration: 14 nM
Beside the measured number, compound 4's estimate is 11-fold (1.03 log units) above it, outside the stated range (below it).
By their numbers in this assay, from the lowest: compound 1; then compound 4; then compound 3; then compound 2.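

The aromatic carbon para to a large group accepts isopropoxy, with more heavy atoms than chloro and a hydrogen-bond acceptor that chloro lacks, and the number falls: a 4.7-fold lower number from compound 3 to compound 4 (0.67 log units; beyond the scatter) and a 29-fold lower number from compound 2 to compound 4 (1.46 log units; beyond the scatter). From the lowest number, the order at this carbon is now isopropoxy, chloro, methyl, with every gap beyond the scatter. No measurement here bears on the reason for this order.

Open, on these data alone, is whether the oxygen or the carbon count of isopropoxy goes with the lower number, which methoxy and an isobutyl chain at this carbon would separate.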